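The source may report more compounds than this note shows. Statements on the series, on what has been measured and on what is new or still open speak of the compounds shown alone.

Measured compounds:
- compound 1, `Cc1cccc(NC(=O)N[C@H](C)c2ccccc2)c1`, gives 98%
- compound 2, `Cc1cccc(NC(=O)N[C@@H](C)c2ccccc2)c1`, gives 100%
- compound 3, `CC(C)c1ccccc1NC(=O)N[C@@H](C)c1ccccc1`, gives 96%

All three numbers come from an ADME assay on the whole organism with Oryza sativa as the target, tested at 1 uM; a higher number here means a weaker effect of the compound at the concentration tested, a lower number a stronger effect. Compound 2 sits at the top of the three, but only just: the step of a number 2 percentage points higher from compound 1 to compound 2 (within the scatter) is within the scatter, and compound 3 with its 96% also lies within the scatter of compound 2. For the measured compounds named here, the three compounds therefore read as one cluster near the top of the scale, with no compound separable from another. Compounds 1 and 2 share every atom and bond, a point made plain by the fact that compounds 1 and 2 differ only in the configuration as drawn, so that step says nothing about how a change of a group would play out.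

Compound 4, `CCOC(=O)c1cccc(NC(=O)N[C@@H](C)c2ccccc2)c1`, is the next compound. Its change from compound 2 is ethoxycarbonyl in place of methyl on an aromatic carbon, meta to a large group. Going by the values given here, no measured step concerns a change of this sort; the only step on record is a change of configuration that stayed within the scatter. With all three known numbers near the ceiling, little room remains for a rise, so the expectation is a number near that of compound 2, or somewhat lower. Compound 4 is expected to give about 92%, with a range from 75% to 100%. The step this estimate implies is a number 8 percentage points lower from compound 2 to compound 4 (within the scatter), which is expected to stay within or just beyond the scatter.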

Compound 4, a percentage reported as activity, at one concentration (the size of the read-out at that concentration, not a potency): 99%
Estimate against measurement, compound 4: 7 percentage points below, within the range that was stated.
By their numbers in this assay, from the lowest: compounds 3, 1, 4 and 2 (each within the scatter of the next).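

The change from methyl to ethoxycarbonyl on an aromatic carbon, meta to a large group, is a change of a group, which the one earlier step was not: the fact that compounds 1 and 2 differ only in the configuration as drawn

In this assay, this new change comes out as a number 1 percentage points lower from compound 2 to compound 4 (within the scatter). The entering group brings 5 heavy atoms and 2 hydrogen-bond acceptors where methyl had 1 heavy atom and no acceptor, and yet compound 4 cannot be told apart from compound 2, so at this position and at this one concentration a change of that size in the group leaves no readable mark on the number.

Going by these compounds, what remains open is whether any group at this place can bring the number clearly down, for example an amine, a carboxylic acid or a longer chain in place of the ethoxycarbonyl. Also open, on these data alone, is whether the ethoxycarbonyl compound drawn with the opposite configuration would stay in the same cluster, as the methyl pair of compound 1 and compound 2 does.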